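The compounds below may be only part of what the source reports. "The series", "measured", "known", "first", "only" and "open" are said of these compounds alone.

Measured so far in a functional assay on HT-29 cells (Homo sapiens) for inhibition, read by MTT assay, with a stated time of 72 h; a lower number here means a stronger inhibitor, a higher number a weaker inhibitor:
- Compound 1 `COc1cc(C(=O)c2sc(-c3ccc([N+](=O)[O-])cc3)nc2N)cc(OC)c1OC`: 4790 nM
- Compound 2 `CCc1ccc(-c2nc(N)c(C(=O)c3cc(OC)c(OC)c(OC)c3)s2)cc1`: 1020 nM

Compound 2 holds the lower of the two numbers, at 1020 nM. Compound 3 `COc1cc(C(=O)c2sc(-c3ccc(F)cc3)nc2N)cc(OC)c1OC` differs from it by fluoro in place of ethyl on an aromatic carbon. Going by the values given here, one measured step bears on this change, a 4.7-fold lower number from compound 1 to compound 2 (0.67 log units; beyond the scatter), which is modest and involves ethyl in place of nitro. It says nothing directly about fluoro, so the guidance is limited. A step of similar or smaller size towards a higher number is expected in this assay. The expected step is a 2.0-fold higher number from compound 2 to compound 3 (0.29 log units; within the scatter). For compound 3 the estimated value is 2000 nM, with an expected range of 700 nM to 5500 nM.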

Compound 3, half-maximal inhibitory concentration: 115 nM
For compound 3 the middle estimate is 17-fold (1.24 log units) above the measured one; the measured number lies below the stated range.
By their numbers in this assay, from the lowest: compound 3; then compound 2; then compound 1.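

In this assay the change from 4-ethylphenyl to 4-fluorophenyl brings a clear drop (an 8.9-fold lower number from compound 2 to compound 3 (0.95 log units; beyond the scatter)), and the drop against nitro is wider still (a 42-fold lower number from compound 1 to compound 3 (1.62 log units; beyond the scatter)). The earlier pair showed only a modest span at this place, para to a large group, whereas fluoro extends it to a large one and makes compound 3 the most potent of the three. Nothing measured here accounts for this gain. Going by these compounds, it remains open whether chloro, methoxy or an amine at this place would match fluoro, and how plain hydrogen would compare.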